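Nucleoside analogues and their tolerance by liver cells

This account rests on a few compounds, and the source may have more. Where it says the series, first, only, none or still open, it means among the compounds named here.

compound 1, `CC(=O)N(Cc1ccccc1)Cc1ncnc2c1ncn2[C@@H]1O[C@H](CO)[C@@H](O)[C@H]1O`: > 100000 nM
compound 2, `O=C(O)CNCc1ncnc2c1ncn2[C@@H]1O[C@H](CO)[C@@H](O)[C@H]1O`: > 100000 nM

In a functional assay on Huh-7 cells (Homo sapiens) for cytotoxicity, read by MTT assay, with a stated time of 3 days (a higher number here means that more compound is tolerated, a lower number that less compound is tolerated), compound 1 reaches only a limit of the assay, > 100000 nM, not a number. Compound 2 likewise stands at a limit, > 100000 nM. For the measured compounds named here, both values share (the limit of > 100000 nM in this assay, at which 2 of the 2 values shown sit), so no measured step separates them. Compound 3, `CN(Cc1ncnc2c1ncn2[C@@H]1O[C@H](CO)[C@@H](O)[C@H]1O)c1ccccc1`, differs from compound 2 by methyl(phenyl)amino in place of (carboxymethyl)amino on a saturated chain carbon bound to an aromatic carbon. With no measured step among the compounds shown, no change beyond the usual scatter is expected in this assay. Compound 3 is thus expected to give 100000 nM, between 30000 nM and 300000 nM. That estimate means an expected step of a number no higher from compound 2 to compound 3 (the limit leaves the size open), none beyond the scatter.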

Compound 3, half-maximal cytotoxic concentration: 21000 nM
Estimate against measurement, compound 3: 4.8-fold (0.68 log units) above, and the stated range ends above it.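

In this assay, the place on a saturated chain carbon bound to an aromatic carbon proves able to shift tolerance: methyl(phenyl)amino in place of (carboxymethyl)amino brings an at least 4.7-fold lower number from compound 2 to compound 3 (0.67 log units; beyond the scatter). For the compounds shown here, compound 3 thus gives the first value here that is a number and not a limit. Compound 2 stands at a limit, so the step fixes only a minimum size: the limit of > 100000 nM in this assay, at which 2 of the 3 values shown sit.

The change replaces the whole group at once, so what the compounds shown leave open is whether the phenyl ring or the absence of the carboxylic acid accounts for the step. From the compounds shown here alone, how a plain methylamino group or a longer chain bearing the carboxylic acid would fare at this place also stays open.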